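This account rests on a few compounds, and the source may have more. Where it says the series, first, only, none or still open, it means among the compounds named here.

Working notes on the series. All compounds share the core of compound 1 `Cc1ncc([N+](=O)[O-])n1CCOC(=O)c1cc(NC(=O)C(C)NC(=O)OCc2ccccc2)ccc1O` and differ only in the group on the saturated chain carbon bound to an amide-type nitrogen and a carbonyl carbon. In a functional assay on the whole organism (strain Wistar) for inhibition, with Rattus norvegicus as the target, read by paw edema, with stated times of 1 h and 3 h, at a dose of 10 mg/kg by the intraperitoneal route (a higher number here means more inhibition at the dose given (going by the name of the read-out), a lower number less inhibition), compound 1 gives 44.8%. Among the measured compounds shown here, compound 2 `Cc1ncc([N+](=O)[O-])n1CCOC(=O)c1cc(NC(=O)[C@H](CCCCN)NC(=O)OCc2ccccc2)ccc1O` gives 36.9% in this assay, which is the lesser of the two numbers so far, but the gap to compound 1 lies within the scatter, so nothing separates the two. Compound 3 `Cc1ncc([N+](=O)[O-])n1CCOC(=O)c1cc(NC(=O)CNC(=O)OCc2ccccc2)ccc1O` has not been measured; it differs from compound 2 by hydrogen in place of 4-aminobutyl on a saturated chain carbon bound to an amide-type nitrogen and a carbonyl carbon. For the measured compounds named here, no measured pair supplies a step of this kind. Because compound 1 gives 44.8% and compound 2 gives 36.9% with both values within the scatter of each other, no move beyond the scatter is expected in either direction. The step of a number 3.1 percentage points higher from compound 2 to compound 3 (within the scatter) is expected to stay within the scatter. Compound 3 is estimated at 40% in this assay, with a range from 25% to 55%.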

Compound 3, a percentage reported as inhibition, in the whole organism at one dose (the size of the read-out at that dose, not a potency): 57%
Compound 3: middle estimate off by 17 percentage points, on the low side; the whole stated range lies below it.
By their numbers in this assay, from the lowest: compounds 2 and 1 (each within the scatter of the next); then compound 3.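

In this assay, this position now shows a response to the change: hydrogen in place of 4-aminobutyl gives a number 20.1 percentage points higher from compound 2 to compound 3 (beyond the scatter), and hydrogen in place of methyl gives a number 12.2 percentage points higher from compound 1 to compound 3 (beyond the scatter). Compound 3, with only hydrogen on the saturated chain carbon, thus stands apart from both substituted compounds, whereas compound 1 and compound 2 stay within the scatter of each other, so in these three compounds hydrogen against a group separates the numbers, while methyl and 4-aminobutyl do not. Nothing available bears on the reason for this difference.

Open, as far as these compounds go, is whether a plain butyl chain without the amine, or a carboxylic acid on this carbon, would fall with compound 3 or with the two substituted compounds. The shown compounds also leave open how a ring on this carbon would read out.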